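Bromophenol series: trifluoromethyl in place of chloro

The source may report more compounds than this note shows. Statements on the series, on what has been measured and on what is new or still open speak of the compounds shown alone.

For the measured compounds named here, compound 1 `C=C1C[C@]23C[C@@]1(O)CC[C@H]2c1cc(Br)c(O)c(C)c1[C@@H]3Cn1cc(-c2ccc(Cl)cc2)nn1` carries the only number in a functional assay on SMMC-7721 cells (Homo sapiens) for cytotoxicity, read by MTT assay, with a stated time of 4 days; on this read-out lower numbers stand for stronger inhibition and higher numbers for weaker inhibition: compound 1 gives 19100 nM. Compound 3 `C=C1C[C@]23C[C@@]1(O)CC[C@H]2c1ccc(O)c(C)c1[C@@H]3Cn1cc(-c2ccc(Cl)cc2)nn1` reaches only a limit, > 20000 nM. Compound 2 `C=C1C[C@]23C[C@@]1(O)CC[C@H]2c1ccc(OS(=O)(=O)c2ccc(C)cc2)c(C)c1[C@@H]3Cn1cc(-c2ccc(F)cc2)nn1` likewise stops at a limit, > 20000 nM. Going by the values given here, the one measured step, an at least 1.0-fold higher number from compound 1 to compound 3 (0.01 log units; that floor lies within the scatter), is bounded by the limit of > 20000 nM in this assay, at which 2 of the 3 values shown sit. Compound 4 `C=C1C[C@]23C[C@@]1(O)CC[C@H]2c1cc(Br)c(O)c(C)c1[C@@H]3Cn1cc(-c2ccc(C(F)(F)F)cc2)nn1` differs from compound 1 by trifluoromethyl in place of chloro on an aromatic carbon. Among the compounds with values here, no measured step touches the 4-chlorophenyl; the change from compound 1 to compound 3 concerns bromo on the shared core and says nothing about this ring. The expectation is therefore a step of a 1.0-fold lower number from compound 1 to compound 4 (0.00 log units; within the scatter), none beyond the scatter. Compound 4 is estimated at 19000 nM, with a range of 8000 nM to 45000 nM, and a fair chance that only a limit is reported.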

Compound 4, half-maximal inhibitory concentration: 12800 nM
For compound 4 the middle estimate is 1.5-fold (0.17 log units) above the measured one, within the range that was stated.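

For the compounds shown here, the step, a 1.5-fold lower number from compound 1 to compound 4 (0.17 log units; within the scatter), is the first read on the 4-chlorophenyl ring in this assay, and it gives this position no measurable change. With bromo kept on the shared core, trifluoromethyl in place of chloro still yields a number rather than a limit, although the series remains weak overall: the limit of > 20000 nM in this assay, at which 2 of the 4 values shown sit.

Going by these compounds, whether an amine or a carboxylic acid on this ring would move the number beyond the scatter stays open. Also open, on these data alone, is whether bromo matters in the same way alongside 4-(trifluoromethyl)phenyl.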